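Acetyl to propanoyl on a shared pyrazoline-pyrazole scaffold

This account rests on a few compounds, and the source may have more. Where it says the series, first, only, none or still open, it means among the compounds named here.

Compound 1: `CC(=O)N1N=C(c2ccc(F)cc2)CC1c1cn(-c2ccccc2)nc1-c1ccc(Cl)c(Cl)c1`, 45.7%
Compound 2: `CC(=O)N1N=C(c2ccc(Cl)cc2)CC1c1cn(-c2ccccc2)nc1-c1ccc(Cl)c(Cl)c1`, 45.7%

In a functional assay on the whole organism (strain Wistar) for inhibition, with Rattus norvegicus as the target, read by paw edema, with a stated time of 30 min, at a dose of 50 mg/kg by the oral route (on this read-out higher numbers stand for more inhibition at the one dose given (going by the name of the read-out) and lower numbers for less inhibition), compound 1 gives 45.7% and compound 2 gives 45.7%. The one measured step, no change at the digits printed from compound 1 to compound 2 (within the scatter), is a chloro in place of fluoro on an aromatic carbon, so compound 2 stands level with compound 1 at the digits shown, the two values lying within the scatter of each other.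

Compound 3, `CCC(=O)N1N=C(c2ccc(Cl)cc2)CC1c1cn(-c2ccccc2)nc1-c1ccc(Cl)c(Cl)c1`, differs from compound 2 by methyl in place of hydrogen on a saturated chain carbon bound to a carbonyl carbon. Among the compounds with values here, no measured step touches this part of the shared core, and the halogen swap gives no guide to it, since it lies elsewhere on the molecule. With nothing to point either way, no step beyond the scatter is expected in this assay, and the estimated step of a number 0.3 percentage points higher from compound 2 to compound 3 (within the scatter) is set near zero. Compound 3 is therefore expected to give about 46%, within a range from 30% to 60%.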

Compound 3, a percentage reported as inhibition, in the whole organism at one dose (the size of the read-out at that dose, not a potency): 47.9%
Compound 3: middle estimate off by 1.9 percentage points, on the low side; the range from low to high includes it.
By their numbers in this assay, from the lowest: compounds 1, 2 and 3 (each within the scatter of the next).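

In this assay, the first change shown at this position, methyl in place of hydrogen on a saturated chain carbon bound to a carbonyl carbon, gives a number 2.2 percentage points higher from compound 2 to compound 3 (within the scatter) and so leaves the read-out within the scatter. Within the data shown here, the earlier step, no change at the digits printed from compound 1 to compound 2 (within the scatter), concerned only a halogen on an aromatic carbon, so this is the first sign that the acetyl group can become propanoyl without a step beyond the scatter. No supporting data bear on why this position behaves this way.

Going by these compounds, a single added methyl says little about larger changes here, so it remains open whether a longer chain such as butanoyl or a ring such as cyclopropyl or phenyl on the carbonyl carbon would hold the read-out level. Also open, on these data alone, is how an amine or a carboxylic acid on this chain would read at this one dose.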